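Compound 1 to compound 4: swapping the aryl group

The source may hold more compounds than are shown below. What is called first, only, known or untested is meant among the compounds shown, and "the series" means these compounds.

Values in a functional assay on DU-145 cells (Homo sapiens) for antiproliferative activity, read by MTT assay, with a stated time of 48 h (a lower number here means a stronger inhibitor, a higher number a weaker inhibitor), for the series
compound 1 `C/C(=C\CC/C(C)=C/CC[C@@H]1[C@@]2(C)CCC(=O)C(C)(C)[C@H]2CC[C@@]1(C)O)CC/C=C(\C)C(=O)OCc1cn(-c2ccccc2C(F)(F)F)nn1` gives > 150000 nM as a limit of the assay, not a number
compound 2 `C/C(=C\CC/C(C)=C/CC[C@@H]1[C@@]2(C)CCC(=O)C(C)(C)[C@H]2CC[C@@]1(C)O)CC/C=C(\C)C(=O)OCc1cn(C[C@@H]2O[C@H](n3ccc(=O)[nH]c3=O)C[C@H]2O)nn1` gives 33100 nM as a number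
compound 3 `C#CCOC(=O)/C(C)=C/CC/C(C)=C/CC/C(C)=C/CC[C@@H]1[C@@]2(C)CCC(=O)C(C)(C)[C@H]2CC[C@@]1(C)O` gives 46100 nM as a number

Compound 1 stands only at a limit, (the limit of > 150000 nM in this assay, at which 1 of the 3 values shown sits), and has no number of its own. Compound 4 `C/C(=C\CC/C(C)=C/CC[C@@H]1[C@@]2(C)CCC(=O)C(C)(C)[C@H]2CC[C@@]1(C)O)CC/C=C(\C)C(=O)OCc1cn(-c2cccc([N+](=O)[O-])c2)nn1` keeps the core of compound 1 and changes one place, on an aromatic nitrogen of a five-membered aromatic ring with 3 nitrogen. There, 3-nitrophenyl stands in place of 2-(trifluoromethyl)phenyl (3-nitrophenyl in place of 2-(trifluoromethyl)phenyl on an aromatic nitrogen). Both groups carry one six-membered aromatic ring of carbon only, and neither has a net charge.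

Within the data shown here, no measured pair isolates a change of this kind, so the expectation for this assay is loose. The numbers available come from compound 2 with 33100 nM and compound 3 with 46100 nM, and these two lie within the usual scatter of each other. A modest move toward stronger inhibition is expected, with a real chance that compound 4 also returns only a limit. The estimated change is an at least 1.8-fold lower number from compound 1 to compound 4 (0.27 log units; that floor lies within the scatter), and it is uncertain. For compound 4 the expected value is 80000 nM, with an estimated range from 30000 nM to 150000 nM.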

Compound 4, half-maximal inhibitory concentration: > 150000 nM
Compound 4: no number, only a limit (the forecaster's own chance of this, stated with the estimate: 35%); middle value at least 1.8-fold (0.27 log units) away from the limit.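

In this assay, compound 1 and compound 4 each return only a limit, not a number, so no step can be read for 3-nitrophenyl in place of 2-(trifluoromethyl)phenyl on an aromatic nitrogen: the limit of > 150000 nM in this assay, at which 2 of the 4 values shown sit.

The compounds shown leave open whether these two groups differ at all in this assay.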